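This account rests on a few compounds, and the source may have more. Where it says the series, first, only, none or still open, it means among the compounds named here.

Measured in a physicochemical assay for solubility, in phosphate buffer, measured as thermodynamic solubility, at pH 7.4; a higher number here means a more soluble compound, a lower number a less soluble compound:
- Compound 1 `CS(=O)(=O)NC(=O)CCc1cn(-c2ccc(Br)cc2)nc1-c1ccc(Cl)cc1`: 170000 nM
- Compound 2 `CS(=O)(=O)NC(=O)CCc1cn(-c2cccc(Br)c2)nc1-c1ccc(Cl)cc1`: < 5000 nM (a limit of the assay, not a number)
- Compound 3 `CS(=O)(=O)NC(=O)CCc1cn(-c2ccc(C(F)(F)F)cc2)nc1-c1ccc(Cl)cc1`: 50000 nM

In this assay, compound 1 holds the higher of the two actual numbers, 170000 nM. The nearest value lies a modest step away, a 3.4-fold lower number from compound 1 to compound 3 (0.53 log units; beyond the scatter).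

Compound 4 `CS(=O)(=O)NC(=O)CCc1cn(-c2ccc(Br)cc2)nc1-c1ccccc1` has hydrogen in place of chloro on an aromatic carbon, so that 4-chlorophenyl becomes phenyl: hydrogen in place of chloro on an aromatic carbon. Going by the values given here, no measured step makes this change. The closest is the replacement of bromo by trifluoromethyl on an aromatic carbon, which gave a modest step, a 3.4-fold lower number from compound 1 to compound 3 (0.53 log units; beyond the scatter). A larger shift came with 3-bromophenyl in place of 4-bromophenyl, an at least 34-fold lower number from compound 1 to compound 2 (1.53 log units; beyond the scatter), and this argues for a wide range.

A modest step toward a higher number is therefore expected in this assay, although the measured steps do not settle the direction. The expected step is a 1.8-fold higher number from compound 1 to compound 4 (0.25 log units; within the scatter). The estimate for compound 4 is 300000 nM, with an expected range of 100000 nM to 900000 nM.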

Compound 4, solubility: 200000 nM
Estimate against measurement, compound 4: 1.5-fold (0.18 log units) above; low and high end bracket the measured number.
By their numbers in this assay, from the lowest: compound 3; then compounds 1 and 4 (each within the scatter of the next). At a limit, below all of these: compound 2.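

In this assay, hydrogen in place of chloro on the aromatic carbon, which turns 4-chlorophenyl into phenyl, gives a 1.2-fold higher number from compound 1 to compound 4 (0.07 log units; within the scatter) and so leaves the number where the scatter cannot separate compound 1 from compound 4. Going by these compounds alone, every earlier step changed the group on the aromatic nitrogen and lay beyond the scatter, so this is the first look at the other aromatic ring, and the loss of chloro there gives no step that can be read as a change. Nothing shown gives a reason for this outcome.

From the compounds shown here alone, whether a methoxy group, an amine or a carboxylic acid at this place would move the number stays open. Also open, going by these compounds, is whether losing chloro would read the same with the 3-bromophenyl of compound 2 or the 4-(trifluoromethyl)phenyl of compound 3 on the aromatic nitrogen.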